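A few compounds are considered here, and "the series" means these few. Any claim that something is new, unique, unknown or untested is made for them only; others in the source may bear on it.

In a functional assay on MCF7 cells (Homo sapiens) for cytotoxicity, read by MTT assay, with a stated time of 4 h (a higher number here means a weaker inhibitor, a lower number a stronger inhibitor), compound 1 `Cn1cc(C(=O)N/N=C\c2c[nH]c3ccccc23)c2cc(Br)ccc21` gives "not active" (no number reported), with no number reported. Among the compounds with values here, compound 2 `Cn1cc(/C=N\NC(=O)c2cn(C)c3ccccc23)c2ccccc21` gives 31300 nM, the only number available so far. Compound 3 `Cn1cc(/C=N\NC(=O)c2cn(C)c3ccc(Br)cc23)c2ccccc21` differs from compound 2 by bromo in place of hydrogen on an aromatic carbon. Within the data shown here, compound 1 also carries a bromo, but no measured step isolates this change, so the data give no firm direction. The expected 1.1-fold higher number from compound 2 to compound 3 (0.05 log units; within the scatter) is no larger than the scatter. For compound 3 the estimated value is 35000 nM, with an expected range of 12000 nM to 100000 nM.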

Compound 3, half-maximal inhibitory concentration: 1190 nM
Estimate against measurement, compound 3: 29-fold (1.47 log units) above; measured number outside the range, below it.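

In this assay, within the data shown here, this aromatic carbon, meta to a fused ring and para to a fused ring, proves sensitive to substitution: bromo in place of hydrogen gives a 26-fold lower number from compound 2 to compound 3 (1.42 log units; beyond the scatter), the first step and one beyond the scatter. Bromo does not by itself ensure a number, since compound 1, which also carries a bromo, gives "not active" (no number reported). No measurement on hand accounts for the step.

Open, as far as these compounds go, is whether this gain is specific to bromo or would also appear with chloro, methoxy or an amine on the same carbon.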